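A few compounds are considered here, and "the series" means these few. Any claim that something is new, unique, unknown or untested is made for them only; others in the source may bear on it.

Measured compounds
Compound 1 `O=c1[nH]cnc2c1c(-c1cccs1)cn2[C@@H]1O[C@H](CO)[C@@H](O)[C@H]1O`: in a functional assay on K562 cells (Homo sapiens), read by MTT assay, with a stated time of 72 h (on this read-out lower numbers stand for stronger inhibition and higher numbers for weaker inhibition), compound 1 gives > 20000 nM, which is a limit of the assay and not a number.
Compound 2 `O=c1[nH]cnc2c1c(-c1cc3ccccc3o1)cn2[C@@H]1O[C@H](CO)[C@@H](O)[C@H]1O`: in this assay compound 2 gives > 20000 nM, again a limit rather than a number.
Compound 3 `CN(C)c1ncnc2c1c(-c1cccs1)cn2[C@@H]1O[C@H](CO)[C@@H](O)[C@H]1O`: in this assay compound 3 gives > 20000 nM, also a limit.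

Compounds 1 and 2 share one core and differ by 1-benzofuran-2-yl in place of thiophen-2-yl on an aromatic carbon. The step that the two limits leave unreadable from compound 1 to compound 2 cannot be sized, because the limit of > 20000 nM in this assay, at which 3 of the 3 values shown sit, leaves both ends of the comparison as limits. Compound 3 carries a different core from compound 1; how the two cores differ is not broken down here. Compound 3 stands at the same limit as the other two, so no ordering among the three measured compounds can be read.

Compound 4 `CN(C)c1ncnc2c1c(-c1cc3ccccc3o1)cn2[C@@H]1O[C@H](CO)[C@@H](O)[C@H]1O` is not yet measured. It arises from compound 3 by 1-benzofuran-2-yl in place of thiophen-2-yl on an aromatic carbon, the same change that leads from compound 1 to compound 2, made at a place described in identical words. Since the measured version of this change gave only a limit at both ends, and since compound 3 itself sits at the limit > 20000 nM, the expected step that the limit leaves unreadable from compound 3 to compound 4 in this assay is one that most likely again ends at a limit. For compound 4 the estimate in this assay is therefore 30000 nM, with an expected range from 12000 nM to 100000 nM.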

Compound 4, half-maximal inhibitory concentration: > 20000 nM
Compound 4: only a limit was reported; the forecaster's own chance of this, stated with the estimate: 85%; the middle value does not contradict the limit.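

In this assay compound 4 gives > 20000 nM as a limit of the assay and not a number. For the compounds shown here, no step from compound 3 to compound 4 can be read, because both ends of the comparison are limits: the limit of > 20000 nM in this assay, at which 4 of the 4 values shown sit. The compounds shown leave open how strongly any of the four inhibits and whether 1-benzofuran-2-yl in place of thiophen-2-yl alters the result in this assay at all.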